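Two Methylphenyl Isomers Tested Against One Leukaemia Line

The source may hold more compounds than are shown below. What is called first, only, known or untested is meant among the compounds shown, and "the series" means these compounds.

Compound 1 `NC(=S)N/N=C/c1ccc2ccccc2n1` in a functional assay on HL-60 cells (Homo sapiens) for antiproliferative activity, read by sulforhodamine B assay, with a stated time of 72 h (a higher number here means a weaker inhibitor, a lower number a stronger inhibitor), gives > 100000 nM, which is a limit of the assay. Compound 2 `Cc1ccc(NC(=S)N/N=C/c2ccc3ccccc3n2)cc1` in this assay gives 78300 nM.

Among the compounds with values here, compound 2 holds the only actual number in this assay; the one other result is a limit of > 100000 nM in this assay, at which 1 of the 2 values shown sits, rather than a measured value, so compound 2 has no measured neighbour to rank against. Within the data shown here, the single step available is an at least 1.2-fold lower number from compound 1 to compound 2 (0.10 log units; that floor lies within the scatter), and its floor does not rise above the scatter, so even this step gives no firm direction.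

Compound 3 `Cc1ccccc1NC(=S)N/N=C/c1ccc2ccccc2n1` is built from compound 2 by moving the methyl group on the aryl ring: 2-methylphenyl in place of 4-methylphenyl on an amide-type nitrogen. Among the measured compounds shown here, no measured step in this set moves a substituent around that ring; the only step measured replaced hydrogen by the whole aryl group. There is therefore nothing to suggest a change beyond the scatter, in either direction.

Compound 3 is accordingly expected to give about 80000 nM in this assay, with a plausible range from 30000 nM to 200000 nM, so the expected step from compound 2 to compound 3 is a 1.0-fold higher number from compound 2 to compound 3 (0.01 log units; within the scatter).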

Compound 3, half-maximal inhibitory concentration: 73200 nM
The estimate for compound 3 lay 1.1-fold (0.04 log units) above the measured number; the measured number falls inside the stated range.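

Moving the methyl group around the aryl ring is the first change in this set with a measured number at both ends, and in this assay it gives a 1.1-fold lower number from compound 2 to compound 3 (0.03 log units; within the scatter). Compound 2 and compound 3 therefore cannot be told apart, so for these two isomers the place of the methyl group on the ring on the amide-type nitrogen makes no difference that the data can resolve. The comparison with the unsubstituted thiocarbonyl nitrogen stays just as unsettled, giving only an at least 1.3-fold lower number from compound 1 to compound 3 (0.13 log units; that floor lies within the scatter) and no firm direction, because one end of that step is a limit of the assay and not a number: the limit of > 100000 nM in this assay, at which 1 of the 3 values shown sits.

As far as these compounds go, whether anything other than methyl on the aryl ring, such as a chlorine atom, a methoxy group or a carboxylic acid, would move the number beyond the scatter remains open. Also open, from the compounds shown here alone, is what an amine or a longer chain would do in place of the aryl group on that nitrogen, and whether any change to the shared core would matter more than the change seen here.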